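Substituent on the benzoyl ring: working notes

A few compounds are considered here, and "the series" means these few. Any claim that something is new, unique, unknown or untested is made for them only; others in the source may bear on it.

Measured so far in an assay on microsomes from liver for inhibition of sterol O-acyltransferase 1 (Rattus norvegicus); a lower number here means a stronger inhibitor, a higher number a weaker inhibitor:
compound 1 `CCCCCCCCCCCCn1nnc(C(NC(=O)c2c(C(C)C)cccc2C(C)C)c2ccccc2)n1`, 810 nM
compound 2 `CCCCCCCCCCCCn1nnc(C(NC(=O)c2ccccc2)c2ccccc2)n1`, 350 nM
compound 3 `CCCCCCCCCCCCn1nnc(C(NC(=O)c2ccc(Cl)cc2)c2ccccc2)n1`, 440 nM

Compound 2 gives the lowest number of the three, but compound 3 sits within the scatter of it: a 1.3-fold higher number from compound 2 to compound 3 (0.10 log units; within the scatter). The only gap beyond the scatter is that from the diisopropyl compound, a 2.3-fold lower number from compound 1 to compound 2 (0.36 log units; beyond the scatter); the related change a 1.8-fold lower number from compound 1 to compound 3 (0.27 log units; within the scatter) stays within the scatter.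

Compound 4 `CCCCCCCCCCCCn1nnc(C(NC(=O)c2ccc([N+](=O)[O-])cc2)c2ccccc2)n1` differs from compound 2 in one place: nitro in place of hydrogen on an aromatic carbon. The measured step that bears directly on this is the one in which a chloro group entered the same aromatic carbon, a 1.3-fold higher number from compound 2 to compound 3 (0.10 log units; within the scatter), which did not move the number beyond the scatter. No other substituent on that ring has been measured, so the series gives no indication that a group at this position shifts the readout in either direction. The nitro group is therefore expected to leave the number about where compound 2 stands, with a step of a 1.2-fold higher number from compound 2 to compound 4 (0.08 log units; within the scatter) that is not expected to exceed the scatter.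

Compound 4 is estimated at 420 nM in this assay, with a range from 200 nM to 900 nM.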

Compound 4, half-maximal inhibitory concentration: 540 nM
Compound 4: middle estimate off by 1.3-fold (0.11 log units), on the low side, and the stated range covers the measured number.
By their numbers in this assay, from the lowest: compounds 2, 3, 4 and 1 (each within the scatter of the next, the first and the last beyond it).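

In this assay, nitro on the aromatic carbon para to a large group is a second substituent at this place that stays within the scatter of hydrogen (a 1.5-fold higher number from compound 2 to compound 4 (0.19 log units; within the scatter)) and also within the scatter of chloro (a 1.2-fold higher number from compound 3 to compound 4 (0.09 log units; within the scatter)), so hydrogen, chloro and nitro cannot be told apart here by this read-out. The nitro compound also stays within the scatter of the 2,6-diisopropylphenyl compound (a 1.5-fold lower number from compound 1 to compound 4 (0.18 log units; within the scatter)), as the chloro compound does (a 1.8-fold lower number from compound 1 to compound 3 (0.27 log units; within the scatter)), which leaves the step from compound 1 to compound 2 as the only one in the series beyond the scatter (a 2.3-fold lower number from compound 1 to compound 2 (0.36 log units; beyond the scatter)). Nothing available explains why these substituents read alike in this assay.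

Still open, going by these compounds, is whether any group at this place can move the number beyond the scatter of compound 2, for instance an amine, a carboxylic acid or a methoxy group. The compounds shown also leave open how a substituent elsewhere on the benzoyl ring, or a shorter chain on the shared core, would read.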